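Replacing the aromatic group of compound 1

A few compounds are considered here, and "the series" means these few. Any claim that something is new, unique, unknown or untested is made for them only; others in the source may bear on it.

In a functional assay on HT-29 cells (Homo sapiens) for inhibition, read by sulforhodamine B assay, with a stated time of 72 h (on this read-out lower numbers stand for stronger inhibition and higher numbers for weaker inhibition), compound 1 (`COc1cc2c(Nc3ccc(F)c(Cl)c3)ncnc2cc1OCCCn1ccnc1[N+](=O)[O-]`) gives 6140 nM and lies within the scatter of the other two measured compounds (compound 2 `COc1cc2c(Nc3ccc(F)c(Cl)c3)ncnc2cc1OCCCCCCn1ccnc1[N+](=O)[O-]` gives 5630 nM and compound 3 `COc1cc2c(Nc3ccc(OCc4cccc(F)c4)c(Cl)c3)ncnc2cc1OCCCn1ccnc1[N+](=O)[O-]` gives 3790 nM). Compound 4 (`COc1cc2c(Nc3cccc(Br)c3)ncnc2cc1OCCCn1ccnc1[N+](=O)[O-]`) differs from compound 1 by one change: 3-bromophenyl in place of 3-chloro-4-fluorophenyl on a nitrogen on an aromatic ring. The nearest measured evidence is the change on that same aromatic group (a 1.6-fold lower number from compound 1 to compound 3 (0.21 log units; within the scatter)). The chain change (a 1.1-fold lower number from compound 1 to compound 2 (0.04 log units; within the scatter)) lies elsewhere and bears on it only weakly. Among the measured compounds shown here, no measured compound carries 3-bromophenyl, so the expectation in this assay is for no move beyond the scatter. The expected step is small (a 1.1-fold lower number from compound 1 to compound 4 (0.05 log units; within the scatter)). Compound 4 is estimated at 5500 nM (expected range 2700 nM to 11000 nM).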

Compound 4, half-maximal inhibitory concentration: 10900 nM
Compound 4: the middle estimate sits 2.0-fold (0.30 log units) below what was measured; low and high end bracket the measured number.
By their numbers in this assay, from the lowest: compounds 3, 2, 1 and 4 (each within the scatter of the next, the first and the last beyond it).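

In this assay, the change to 3-bromophenyl on the nitrogen (a 1.8-fold higher number from compound 1 to compound 4 (0.25 log units; within the scatter)) stays within the scatter. Compounds 2 and 3 both kept the chlorine of the aromatic group, whereas compound 4 carries neither the chloro nor the fluoro of 3-chloro-4-fluorophenyl, and its step still does not leave the scatter. No measurement shown here offers an explanation for this step. On these data alone, it remains open how an amine or a carboxylic acid on this aromatic group would read. Also open, as far as these compounds go, is whether 3-bromophenyl would behave the same on the longer chain of compound 2.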